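This account rests on a few compounds, and the source may have more. Where it says the series, first, only, none or still open, it means among the compounds named here.

Compound 1 `COc1ccc(-c2csc(N)c2C(=O)OCc2ccccc2)cc1OC` gives 100% in an assay on isolated protein for inhibition of protein kinase C zeta type (Homo sapiens), with stated times of 1 h and 2.5 min, tested at 30 uM; on this read-out higher numbers stand for more inhibition at the one concentration tested (going by the name of the read-out) and lower numbers for less inhibition. Compound 2 `COc1ccc(-c2csc(N)c2C(=O)OCc2ccc(F)cc2)cc1OC` carries fluoro in place of hydrogen on an aromatic carbon, with the place described as para to a large group; in this assay compound 2 gives 2%, and the step of a number 98 percentage points lower from compound 1 to compound 2 (beyond the scatter). Compound 3 `CCOC(=O)c1c(-c2ccc(OC)cc2)csc1N` gives 100% in this assay, which stands level with compound 1 within the usual scatter; the difference between the two cores is not broken down here. Compound 4 `CCOC(=O)c1c(-c2ccc(OC)cc2F)csc1N` has not yet been measured in this assay. It carries fluoro in place of hydrogen on an aromatic carbon, with the place described as ortho to a large group and meta to a methoxy group. Among the compounds with values here, this is the same kind of change as the one from compound 1 to compound 2, but not the same, since the surroundings of the place differ. A lower value is expected for compound 4 because a number 98 percentage points lower from compound 1 to compound 2 (beyond the scatter) in the one earlier case of this kind of change. The expected step is a number 55 percentage points lower from compound 3 to compound 4 (beyond the scatter). Compound 4 is therefore estimated to give 45%, with the estimate spanning 5% to 95%.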

Compound 4, a percentage reported as inhibition, at one concentration (the size of the read-out at that concentration, not a potency): 100%
For compound 4 the middle estimate is 55 percentage points below the measured one, and the stated range ends below it.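

In this assay, the new result for fluoro in place of hydrogen on an aromatic carbon is no change at the digits printed from compound 3 to compound 4 (within the scatter). Set beside the earlier step, this shows that the change does not carry a single outcome from one core to the other in this series: the same change on two cores in this assay, a number 98 percentage points lower (beyond the scatter) from compound 1 to compound 2 and no change at the digits printed (within the scatter) from compound 3 to compound 4, 98 percentage points apart, beyond the scatter of two such steps. It does not show what separates the two cases, as the cores differ and so do the places, which are described as para to a large group in compound 2 and as ortho to a large group and meta to a methoxy group in compound 4.

The compounds shown leave open how the same change would read at the other place on each core, and whether chloro or methyl at these places would follow the fluoro results. They also leave open what an amine or a carboxylic acid in place of the ester would do, and with one step on each core, no rule can be stated for either.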